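The source may hold more compounds than are shown below. What is called first, only, known or untested is meant among the compounds shown, and "the series" means these compounds.

Compound 1 `COc1cc(-c2cc(/C=C/C(=O)c3ccc(N)cc3)[nH]n2)cc(OC)c1OC` is a chalcone-type entry in the series. In a functional assay on HCT-116 cells (Homo sapiens) for cytotoxicity, read by sulforhodamine B assay, with a stated time of 48 h, tested at 0.1 uM (on this read-out higher numbers stand for a weaker effect at the one concentration tested and lower numbers for a stronger effect), compound 1 gives 97%, and compound 2 `COc1ccc(-c2cc(/C=C/C(=O)c3ccc(OC)c(OC)c3)[nH]n2)cc1` in this assay gives 105%; the two numbers lie within the usual scatter of each other, so neither shows a clear effect at the single concentration tested. Compound 3 `COc1cc(-c2cc(/C=C/C(=O)c3ccc(Cl)c(Cl)c3)[nH]n2)cc(OC)c1OC` is not yet measured. Its change from compound 1 is 3,4-dichlorophenyl in place of 4-aminophenyl on a carbonyl carbon. For the measured compounds named here, no measured pair covers such a change here, so no step beyond the scatter is expected in this assay, a number 1 percentage points higher from compound 1 to compound 3 (within the scatter). Compound 3 is estimated at 98%, with a range from 84% to 110%.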

Compound 3, a percentage reported as activity, at one concentration (the size of the read-out at that concentration, not a potency): 100%
Compound 3: the middle estimate sits 2 percentage points below what was measured; measured number inside the range.
By their numbers in this assay, from the lowest: compounds 1, 3 and 2 (each within the scatter of the next).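

In this assay, for the compounds shown here, 3,4-dichlorophenyl in place of 4-aminophenyl on the carbonyl carbon gives a number 3 percentage points higher from compound 1 to compound 3 (within the scatter) and so provides the first readable step at this position. Even with the hydrogen-bond donor and acceptor of 4-aminophenyl gone and chlorine entered, the step stays within the scatter at this single concentration. No measured evidence on any property of these groups accompanies the result.

On these data alone, whether a carboxylic acid or a morpholine on the carbonyl carbon would shift the read-out remains open. So does whether the shared core gives any effect at a higher concentration.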